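The source may report more compounds than this note shows. Statements on the series, on what has been measured and on what is new or still open speak of the compounds shown alone.

Compound 2 `O=C(Nc1ccc(Cl)c(-c2nnc3c(Cl)cccn23)c1)c1ccc(Cl)cc1` is one of three amides built on the same core. In a functional assay on MDA-MB-468 cells (Homo sapiens) for antiproliferative activity, read by MTT assay, with a stated time of 72 h (a higher number here means a weaker inhibitor, a lower number a stronger inhibitor), compound 2 reaches only a limit, > 100000 nM, so no number is known for it. Compound 1 `Cc1nc(C(=O)Nc2ccc(Cl)c(-c3nnc4c(Cl)cccn34)c2)cs1` also stops at a limit in this assay, > 100000 nM. Among the compounds with values here, compound 3 `O=C(Nc1ccc(Cl)c(-c2nnc3c(Cl)cccn23)c1)c1c(F)cccc1Cl` is the one member that gives a number, 57600 nM. Accordingly the step that the two limits leave unreadable from compound 1 to compound 2 cannot be read, whereas an at least 1.7-fold lower number from compound 2 to compound 3 (0.23 log units; that floor lies within the scatter) and an at least 1.7-fold lower number from compound 1 to compound 3 (0.23 log units; that floor lies within the scatter) show only a floor that stays within the scatter; both limit values sit at the limit of > 100000 nM in this assay, at which 2 of the 3 values shown sit.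

Compound 4 `CS(=O)(=O)c1cccc(C(=O)Nc2ccc(Cl)c(-c3nnc4c(Cl)cccn34)c2)c1` differs from compound 2 in one place: 3-(methylsulfonyl)phenyl in place of 4-chlorophenyl on a carbonyl carbon. Within the data shown here, no measured step matches this change, and the two limit values leave the effect of exchanging the group on the carbonyl carbon largely unreadable. Compound 4 is therefore expected to stay weak, near 100000 nM, within 30000 nM to 300000 nM. For compound 4 this means an expected step of a number no higher from compound 2 to compound 4 (the limit leaves the size open), with a high chance that only a limit is reported.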

Compound 4, half-maximal inhibitory concentration: > 100000 nM
Compound 4 was reported as a limit; the forecaster's own chance of this, stated with the estimate: 65%; the middle value sits exactly at the limit.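

With the 3-(methylsulfonyl)phenyl group on the carbonyl carbon, the substituent now carries hydrogen-bond acceptors, which the 4-chlorophenyl group does not, yet in this assay compound 4 reaches only a limit, > 100000 nM. Against the one amide with a number, the result is an at least 1.7-fold higher number from compound 3 to compound 4 (0.23 log units; that floor lies within the scatter), so no clear separation can be claimed. The steps among the amides that stop at the limit cannot be read, and this limit now covers most of the small set: the limit of > 100000 nM in this assay, at which 3 of the 4 values shown sit.

Going by these compounds, it remains open whether a phenyl group carrying an amine or a carboxylic acid would give a number in this assay. Also open, on these data alone, is whether a 2-chlorophenyl or a 2-fluorophenyl group alone would give a number there.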